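This account rests on a few compounds, and the source may have more. Where it says the series, first, only, none or still open, it means among the compounds named here.

Measured compounds in an assay on HEK293 cells for positive allosteric modulation of metabotropic glutamate receptor 3 (Rattus norvegicus), read by thallium flux, with a stated time of 2.5 min; a higher number here means that more compound is needed for the effect, a lower number that less compound is needed:
- compound 2 `CCC(=O)c1ccc(OCCCCOc2cc(C(=O)O)ccc2OC)c(C)c1O`: 6360 nM
- compound 3 `CCCC(=O)c1ccc(OCCCCOc2cc(C(=O)O)ccc2OC)c(C)c1O`: 496 nM
- compound 1 `Cc1c(OCCCCOc2ccc(C(=O)C(C)C)c(O)c2C)cccc1C(=O)O`: "not determined" (no result reported)

Going by the values given here, compound 3 stands lowest of the two numbers in this assay, with compound 2 its only neighbour at a 13-fold lower number from compound 2 to compound 3 (1.11 log units; beyond the scatter). Compound 4 `COc1ccc(C(=O)O)cc1OCCCCOc1ccc(C(=O)C(C)C)c(O)c1C` keeps every atom of compound 3 but rearranges the ketone side chain: isopropyl in place of propyl on a carbonyl carbon. Among the compounds with values here, the only measured step, a 13-fold lower number from compound 2 to compound 3 (1.11 log units; beyond the scatter), concerns the same chain on the same carbonyl carbon, where adding one carbon brought a large gain; it does not test branching. Branching the chain is therefore expected to stay close to compound 3, with a step of a 1.6-fold higher number from compound 3 to compound 4 (0.21 log units; within the scatter) likely inside the scatter. Compound 4 is estimated at 800 nM, between 250 nM and 2500 nM.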

Compound 4, half-maximal effective concentration: 588 nM
Compound 4: middle estimate off by 1.4-fold (0.13 log units), on the high side, within the range that was stated.
By their numbers in this assay, from the lowest: compounds 3 and 4 (each within the scatter of the next); then compound 2.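

Swapping propyl for isopropyl on a carbonyl carbon gives a 1.2-fold higher number from compound 3 to compound 4 (0.07 log units; within the scatter), so the straight and branched chains cannot be told apart here. The large step up from the shorter chain of compound 2 therefore holds for the branched chain as well (an 11-fold lower number from compound 2 to compound 4 (1.03 log units; beyond the scatter)). Nothing measured here explains why the extra carbon matters in either shape. The compounds shown leave open how a longer chain, such as butyl, or a small ring, such as cyclopropyl, would behave on this carbonyl carbon.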